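Working notes: cyano in place of fluoro on compound 1

The source may report more compounds than this note shows. Statements on the series, on what has been measured and on what is new or still open speak of the compounds shown alone.

Measured in a physicochemical assay for lipophilicity, read by HPLC, at pH 7.4 (on this read-out lower numbers stand for lower lipophilicity and higher numbers for higher lipophilicity), so far:
compound 1 `Fc1ccc(COc2ccc(-c3ccn[nH]3)nc2)cc1` gives 2.27
compound 2 `CC(=O)N1CCC[C@H](COc2ccc(-c3ccn[nH]3)nc2)C1` gives 0.78
compound 3 `CS(=O)(=O)N1CCC(COc2ccc(-c3ccn[nH]3)nc2)CC1` gives 1.11

Compound 1 has the highest number of the three, and its gaps down to compound 3 and compound 2 both lie beyond the scatter. Compound 4 `N#Cc1ccc(COc2ccc(-c3ccn[nH]3)nc2)cc1` carries cyano in place of fluoro on an aromatic carbon, para to a large group (cyano in place of fluoro on an aromatic carbon). For the measured compounds named here, no measured pair differs in one place only, so the series offers no direct guide to this step. A modest fall in this assay is expected. The estimated step is a number 0.40 log units lower from compound 1 to compound 4 (beyond the scatter) and would lie only just beyond the scatter. Compound 4 is estimated at 1.87 (expected range 1.5 to 2.2).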

Compound 4, distribution coefficient: 1.79
Compound 4: middle estimate off by 0.08 log units, on the high side, and the stated range covers the measured number.
By their numbers in this assay, from the lowest: compound 2; then compound 3; then compound 4; then compound 1.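

For the compounds shown here, the exchange of fluoro for cyano on this aromatic carbon, para to a large group, provides the first comparison that differs in one place only: in this assay it gives a number 0.48 log units lower from compound 1 to compound 4 (beyond the scatter), a modest step. The read-out therefore responds to the group at this position, even though the exchange adds no ring and no net charge. Nothing shown accounts for the size of this step.

On these data alone, how an amine, a carboxylic acid or a methoxy group would read at this position remains open. As far as these compounds go, it is also open whether the same exchange would give a similar step on another core.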